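Aryl substituent swap: chloro to trifluoromethoxy, microsomal stability

A few compounds are considered here, and "the series" means these few. Any claim that something is new, unique, unknown or untested is made for them only; others in the source may bear on it.

Compound 2 `CC(=O)Nc1cc(-c2ccc(OC[C@@H](N)CC(C)C)c(Cl)c2)ccn1` carries a chloro on the carbon-only aromatic ring; in an ADME assay on microsomes from liver (Rattus norvegicus) for metabolic stability, read by LC-MS, using NADPH, with a stated time of 10 min, tested at 0.5 uM (on this read-out higher numbers stand for a more stable compound and lower numbers for a less stable compound), compound 2 gives 100%. Among the measured compounds shown here, its one measured neighbour is compound 1 `CC(=O)Nc1cc(-c2ccc(OC[C@@H](N)CC(C)C)c(C)c2)ccn1`, the methyl analogue, which in this assay gives 99%; the step of a number 1 percentage points higher from compound 1 to compound 2 (within the scatter) lies within the scatter, so the two numbers are read as the same. Compound 3 `CC(=O)Nc1cc(-c2ccc(OC[C@@H](N)CC(C)C)c(OC(F)(F)F)c2)ccn1` is not yet measured and differs from compound 2 thus: trifluoromethoxy in place of chloro on an aromatic carbon. The chloro leaves and a trifluoromethoxy of 5 heavy atoms enters at the same aromatic carbon. For the measured compounds named here, only the step from compound 1 to compound 2 bears on this, and it showed nothing beyond the scatter, so for compound 3 a step of a number 5 percentage points lower from compound 2 to compound 3 (within the scatter) in this assay that stays within the scatter is expected. Compound 3 is estimated at 95%, between 80% and 100%.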

Compound 3, percent of the compound remaining: 80%
The estimate for compound 3 lay 15 percentage points above the measured number; measured number inside the range.
By their numbers in this assay, from the lowest: compound 3; then compounds 1 and 2 (each within the scatter of the next).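

In this assay this aromatic carbon, ortho to a (2-amino-4-methylpentyl)oxy group, proves not to be indifferent to its substituent: methyl and chloro could not be told apart, but trifluoromethoxy gives a number 20 percentage points lower from compound 2 to compound 3 (beyond the scatter) and a number 19 percentage points lower from compound 1 to compound 3 (beyond the scatter). Both steps lie beyond the scatter, so the change is seen against either of the earlier groups. Nothing available explains why the number falls with this group.

As far as these compounds go, it remains open whether a methoxy or a trifluoromethyl at the same carbon would stay level with compound 1 and compound 2 or fall towards compound 3, which would help separate the role of the oxygen from that of the fluorines. Also open, from the compounds shown here alone, is whether the same swap has a similar effect when the (2-amino-4-methylpentyl)oxy group is replaced by a shorter chain.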